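Trifluoromethyl Added to Compound 3: What to Expect

The source may hold more compounds than are shown below. What is called first, only, known or untested is meant among the compounds shown, and "the series" means these compounds.

Compound 3 `O=C1NC=C(C(=O)NCCCN2CCC(c3ccccn3)CC2)[C@@H](c2ccc(F)c(F)c2)N1` gives the highest number of the three measured compounds in an assay on LM cells with Alpha-1B adrenergic receptor (Homo sapiens) as the target (on this read-out lower numbers stand for stronger inhibition and higher numbers for weaker inhibition), with 1850 nM. Compound 1 `O=C1NC(C(F)(F)F)=C(C(=O)NCCCN2CCC(c3ccc(F)cc3)CC2)[C@@H](c2ccc(F)c(F)c2)N1` gives 270 nM in this assay, and compound 2 `N#Cc1cc(F)ccc1C1CCN(CCCNC(=O)C2=C(C(F)(F)F)NC(=O)N[C@@H]2c2ccc(F)c(F)c2)CC1` gives 200 nM; both gaps to compound 3 lie beyond the scatter. Compound 4 `O=C1NC(C(F)(F)F)=C(C(=O)NCCCN2CCC(c3ccccn3)CC2)[C@@H](c2ccc(F)c(F)c2)N1` is not yet measured; it differs from compound 3 by trifluoromethyl in place of hydrogen on a double-bonded ring carbon. Going by the values given here, the only measured single-point step, a 1.4-fold lower number from compound 1 to compound 2 (0.13 log units; within the scatter), concerns a different position and lies within the scatter, so it says nothing about the present change. Among the compounds with values here, no measured pair isolates the trifluoromethyl: compounds 1 and 2 both carry it and both sit well under compound 3, but they also differ from compound 3 in a second group, so the share of the trifluoromethyl in that gap cannot be separated. Compound 4 is nevertheless expected to come in around 450 nM, in a range from 150 nM to 1300 nM, which is an expected step of a 4.1-fold lower number from compound 3 to compound 4 (0.61 log units; beyond the scatter).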

Compound 4, inhibition constant: > 2000 nM
Compound 4: a limit, no number (the forecaster's own chance of this, stated with the estimate: 2%); at least 4.4-fold (0.64 log units) between middle value and limit.
By their numbers in this assay, from the lowest: compounds 2 and 1 (each within the scatter of the next); then compound 3. At a limit, above all of these: compound 4.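

In this assay compound 4 gives only a limit, not a number: the limit of > 2000 nM in this assay, at which 1 of the 4 values shown sits. Trifluoromethyl in place of hydrogen on this double-bonded ring carbon therefore brings no measurable gain when pyridin-2-yl is present, with an at least 1.0-fold higher number from compound 3 to compound 4 (0.03 log units; that floor lies within the scatter), so the lower numbers of compound 1 and compound 2 cannot be credited to trifluoromethyl alone. With trifluoromethyl held constant, the group on the saturated ring carbon makes a clear difference: pyridin-2-yl in place of 2-cyano-4-fluorophenyl gives an at least 10-fold higher number from compound 2 to compound 4 (1.00 log units; beyond the scatter), and pyridin-2-yl in place of 4-fluorophenyl gives an at least 7.4-fold higher number from compound 1 to compound 4 (0.86 log units; beyond the scatter).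

As far as these compounds go, whether trifluoromethyl actually raises the number with pyridin-2-yl present stays open, and so does its effect with either of the two phenyl groups. Also open, from the compounds shown here alone, is how a smaller methyl group or an amine would behave on the same ring carbon.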